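Benzyl replacements in the disulfonamide series: a naphthyl step

The source may report more compounds than this note shows. Statements on the series, on what has been measured and on what is new or still open speak of the compounds shown alone.

Measured so far in a functional assay on BXPC-3 cells (Homo sapiens) for inhibition, read by MTT assay, with a stated time of 72 h; a lower number here means a stronger inhibitor of growth, a higher number a weaker inhibitor of growth:
compound 1 `O=S(=O)(NCCCNCc1ccccc1Cl)c1cc(C(F)(F)F)cc(C(F)(F)F)c1`, 11000 nM
compound 2 `CC(C)(C)c1ccc(CNCCCNS(=O)(=O)c2cc(C(F)(F)F)cc(C(F)(F)F)c2)cc1`, 1400 nM
compound 3 `O=S(=O)(NCCCNCc1ccccc1)c1cc(C(F)(F)F)cc(C(F)(F)F)c1`, 13000 nM

Compound 2 gives the lowest number of the three in this assay. The step of a 7.9-fold lower number from compound 1 to compound 2 (0.90 log units; beyond the scatter) and the step of a 9.3-fold higher number from compound 2 to compound 3 (0.97 log units; beyond the scatter) both lie beyond the scatter, so compound 2 is separated from compound 1 and from compound 3; compound 1 and compound 3 sit within the scatter of each other, as the step of a 1.2-fold higher number from compound 1 to compound 3 (0.07 log units; within the scatter) shows.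

Compound 4 `O=S(=O)(NCCCNCc1cccc2ccccc12)c1cc(C(F)(F)F)cc(C(F)(F)F)c1` is not yet measured in this assay. It differs from compound 2 by naphthalen-1-yl in place of 4-(tert-butyl)phenyl on a saturated chain carbon bound to an amine nitrogen. Going by the values given here, the steps that bear on this change are those that remove or exchange the group on the same carbon: removing tert-butyl costs a 9.3-fold higher number from compound 2 to compound 3 (0.97 log units; beyond the scatter), and exchanging 2-chlorophenyl for 4-(tert-butyl)phenyl gains a 7.9-fold lower number from compound 1 to compound 2 (0.90 log units; beyond the scatter). Nothing measured tells how a second fused aromatic ring compares with the tert-butyl group, so the expectation is a weaker result than compound 2 but not back to the level of compound 3. For compound 4 the expected step is a 3.6-fold higher number from compound 2 to compound 4 (0.55 log units; beyond the scatter). The estimated value for compound 4 in this assay is 5000 nM, with a range from 1500 nM to 15000 nM.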

Compound 4, concentration for 50% growth inhibition: 2700 nM
Compound 4: the middle estimate sits 1.9-fold (0.27 log units) above what was measured; the range from low to high includes it.
By their numbers in this assay, from the lowest: compounds 2 and 4 (each within the scatter of the next); then compounds 1 and 3 (each within the scatter of the next).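

Working notes: in this assay, the position on the saturated chain carbon bound to an amine nitrogen gives a lower number with a group other than 4-(tert-butyl)phenyl, as naphthalen-1-yl shows a 4.8-fold lower number from compound 3 to compound 4 (0.68 log units; beyond the scatter) and a 4.1-fold lower number from compound 1 to compound 4 (0.61 log units; beyond the scatter), both beyond the scatter. Against the best earlier group the exchange gives a 1.9-fold higher number from compound 2 to compound 4 (0.29 log units; within the scatter), within the scatter, so these two groups of 10 heavy atoms, all carbon, cannot be told apart here, although one carries a single six-membered aromatic ring and the other carries 2 such rings. The lower numbers at this position therefore do not depend on the tert-butyl group itself, though no measurement offered here explains the result.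

Open, going by these compounds, is whether the same position keeps these lower numbers once the carbon-only group bears an amine or a carboxylic acid. Also open, on these data alone, is whether a longer chain in the shared core changes how naphthalen-1-yl and 4-(tert-butyl)phenyl compare.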